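Substituent on the Amide Nitrogen: Hydroxy to Pyrazinyl

A few compounds are considered here, and "the series" means these few. Any claim that something is new, unique, unknown or untested is made for them only; others in the source may bear on it.

Compound 3 `Cc1ccc(OCC(=O)N(O)Cc2cccs2)cc1` gives 8000 nM in an assay on HEK293 cells for agonist activity at transient receptor potential cation channel subfamily M member 8 (Homo sapiens), read by fluorescence and calcium flux, with a stated time of 15 min (on this read-out lower numbers stand for an effect already at smaller amounts and higher numbers for an effect only at larger amounts of compound), the highest number among the three measured; compound 1 `Cc1ccc(OCC(=O)N(Cc2cccs2)C(C)C)cc1` gives 70 nM and compound 2 `Cc1ccc(OCC(=O)N(Cc2cccs2)c2c(C)n[nH]c2C)cc1` gives 0.3 nM. Compound 4 `Cc1ccc(OCC(=O)N(Cc2cccs2)c2cnccn2)cc1` carries the change (pyrazin-2-yl in place of hydroxy on an amide-type nitrogen). Going by the values given here, two measured steps bear on it: a 110-fold higher number from compound 1 to compound 3 (2.06 log units; beyond the scatter) and a 27000-fold higher number from compound 2 to compound 3 (4.43 log units; beyond the scatter), both arising when a carbon substituent on that nitrogen is replaced by hydroxy. Compound 4 reverses this with an aromatic ring, nearer in kind to the 3,5-dimethyl-1H-pyrazol-4-yl of compound 2 than to the isopropyl of compound 1. A large step to a lower number in this assay is therefore expected for compound 4, a 1600-fold lower number from compound 3 to compound 4 (3.20 log units; beyond the scatter). Compound 4 is estimated at 5 nM, within 0.5 nM to 100 nM.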

Compound 4, half-maximal effective concentration: 1240 nM
The estimate for compound 4 lay 250-fold (2.39 log units) below the measured number; measured number above the stated range.
By their numbers in this assay, from the lowest: compound 2; then compound 1; then compound 4; then compound 3.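

In this assay an aromatic ring on the amide-type nitrogen does not by itself bring a low number: replacing hydroxy with pyrazin-2-yl gives only a 6.5-fold lower number from compound 3 to compound 4 (0.81 log units; beyond the scatter) here. The position separates the two aromatic rings widely, with a 4100-fold higher number from compound 2 to compound 4 (3.62 log units; beyond the scatter) on exchanging 3,5-dimethyl-1H-pyrazol-4-yl for pyrazin-2-yl, and the non-aromatic isopropyl also ranks ahead of pyrazin-2-yl, with an 18-fold higher number from compound 1 to compound 4 (1.25 log units; beyond the scatter) on that exchange. Nothing measured here accounts for these gaps.

Open, on these data alone, is whether the low number of compound 2 depends on its two methyl groups or on its ring itself. A plain phenyl or an unsubstituted pyrazol-4-yl on this nitrogen would help to separate the two.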